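The source may hold more compounds than are shown below. What is called first, only, known or untested is meant among the compounds shown, and "the series" means these compounds.

Notes on the series. In an assay on HEK-293T cells for inhibition of diacylglycerol lipase-alpha (Homo sapiens), read by colorimetric assay (on this read-out higher numbers stand for weaker inhibition and lower numbers for stronger inhibition), compound 1 `O=C(CCCCCc1ccccc1)c1nc2ccc(Br)cc2o1` gives 5890 nM. For compound 2 `O=C(CCCCCCc1ccccc1)c1ncc(-c2cccs2)s1` the read-out in this assay is only a limit, > 10000 nM. For compound 3 `CS(=O)(=O)c1cnc(C(=O)CCCCCCc2ccccc2)o1` the read-out in this assay is likewise only a limit, > 10000 nM. Compound 3 thus stands at the limit of > 10000 nM in this assay, at which 2 of the 3 values shown sit, and among the three compounds only compound 1 returns an actual number. For the measured compounds named here, no two measured compounds differ in a single place, so no measured step is available to draw on. Compound 4 `CNC(=O)c1cnc(C(=O)CCCCCCc2ccccc2)o1` differs from compound 3 by methylcarbamoyl in place of methylsulfonyl on an aromatic carbon. Going by the values given here, with no measured step to lean on, the expected step from compound 3 to compound 4 in this assay is small, within the usual scatter, with no direction favoured. The expected step is an at least 1.1-fold lower number from compound 3 to compound 4 (0.04 log units; that floor lies within the scatter). Compound 4 is therefore estimated to give about 9000 nM in this assay, with an expected range from 2500 nM to 30000 nM, and a limit rather than a number is about as likely as not.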

Compound 4, half-maximal inhibitory concentration: > 10000 nM
Compound 4: only a limit was reported; the forecaster's own chance of this, stated with the estimate: 50%; middle value at least 1.1-fold (0.04 log units) away from the limit.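

Compound 3 and compound 4 both return only a limit in this assay, so the step between them cannot be read, and most of the series sits at that limit: the limit of > 10000 nM in this assay, at which 3 of the 4 values shown sit.

The compounds shown leave open whether methylcarbamoyl or methylsulfonyl on this aromatic carbon gives the lower number in this assay.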